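Swapping 4-fluorophenyl for 2-chlorophenyl on a shared core

The compounds below may be only part of what the source reports. "The series", "measured", "known", "first", "only" and "open" are said of these compounds alone.

Measured in a functional assay on HL-60 cells (Homo sapiens) for inhibition, read by MTT assay, with a stated time of 72 h; a higher number here means a weaker inhibitor, a lower number a stronger inhibitor:
- compound 1 `CCc1nc(-c2ccccc2F)c(C(=O)N2CCN(c3cccc(Cl)c3)CC2)o1` gives 139 nM
- compound 2 `CCc1nc(-c2ccc(F)cc2)c(C(=O)N2CCN(c3cccc(Cl)c3)CC2)o1` gives 169 nM

Among the compounds with values here, with only two numbers so far, compound 2 stands level with compound 1, its sole neighbour. Compound 3 `CCc1nc(-c2ccccc2Cl)c(C(=O)N2CCN(c3cccc(Cl)c3)CC2)o1` differs from compound 2 by 2-chlorophenyl in place of 4-fluorophenyl on an aromatic carbon. Within the data shown here, the one measured guide is the swap of 2-fluorophenyl for 4-fluorophenyl, a 1.2-fold higher number from compound 1 to compound 2 (0.08 log units; within the scatter). Among the measured compounds shown here, no chlorine-bearing compound has been measured, so this guide is thin, and no change beyond the scatter is expected in this assay. The expected step is a 1.1-fold lower number from compound 2 to compound 3 (0.05 log units; within the scatter). For compound 3 the estimate is 150 nM, with a range of 60 nM to 380 nM.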

Compound 3, half-maximal inhibitory concentration: 98.9 nM
Estimate against measurement, compound 3: 1.5-fold (0.18 log units) above; measured number inside the range.
By their numbers in this assay, from the lowest: compounds 3, 1 and 2 (each within the scatter of the next).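

With 2-chlorophenyl on this aromatic carbon, the change from 4-fluorophenyl gives a 1.7-fold lower number from compound 2 to compound 3 (0.23 log units; within the scatter) in this assay, and chloro in place of fluoro on the same ring gives a 1.4-fold lower number from compound 1 to compound 3 (0.15 log units; within the scatter) in that assay. This position has now carried a chlorine-bearing phenyl as well as both fluorophenyls, and every step between them stays within the scatter. Nothing available explains the size of these steps. Still open, on these data alone, is whether 4-chlorophenyl would also stay within the scatter. Also open, as far as these compounds go, is whether a phenyl carrying an amine or a carboxylic acid would shift the number beyond it.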